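The source may report more compounds than this note shows. Statements on the series, on what has been measured and on what is new or still open speak of the compounds shown alone.

Compound 1 `CC(=O)Nc1ccc(S(=O)(=O)NNC(=O)c2cccnc2Nc2ccc(Cl)cc2)cc1`: > 100000 nM
Compound 2 `O=C(NNS(=O)(=O)c1ccc(F)cc1)c1cccnc1Nc1ccc(Cl)cc1Cl`: > 100000 nM

Of the compounds shown here, two have been tested in a functional assay on NCI-H226 cells (Homo sapiens) for antiproliferative activity; a lower number here means that less compound is tolerated, a higher number that more compound is tolerated. For compound 1 the result is only a limit of the assay, > 100000 nM, not a measured number. For compound 2 the result is likewise a limit, > 100000 nM. Both values sit at the limit of > 100000 nM in this assay, at which 2 of the 2 values shown sit, so compound 1 cannot be ranked against anything else; all that is known is that neither compound reached the half-lethal point within the tested range.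

Compound 3 `O=C(NNS(=O)(=O)c1ccc(Cl)cc1Cl)c1cccnc1Nc1ccc(Cl)cc1` has not been measured. It differs from compound 1 in one place: 2,4-dichlorophenyl in place of 4-acetamidophenyl on a sulfonyl sulfur. Among the compounds with values here, no measured pair of compounds differs in this same way, so the expected size of the step rests on the limits alone. Given that compound 1 and compound 2 both ended at the same limit (the limit of > 100000 nM in this assay, at which 2 of the 2 values shown sit), the expectation for compound 3 in this assay is no step beyond the usual scatter, in either direction. The estimate for compound 3 is therefore 100000 nM, within a range from 30000 nM to 300000 nM, and the expected step is a number no higher from compound 1 to compound 3 (the limit leaves the size open), with a limit rather than a number the most likely outcome.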

Compound 3, concentration lethal to 50% of the cells: > 100000 nM
Compound 3 ended at the assay's limit (the forecaster's own chance of this, stated with the estimate: 80%); the middle value lies on the limit itself.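

No step from compound 1 to compound 3 can be read in this assay, since both ended at a limit of the assay rather than at a number: the limit of > 100000 nM in this assay, at which 3 of the 3 values shown sit.

The compounds shown leave open whether 2,4-dichlorophenyl in place of 4-acetamidophenyl changes anything in this assay, and how much of any of these compounds the cells would tolerate.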